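A Methyl on the Phenyl: From Compound 1 to Compound 4

The source may hold more compounds than are shown below. What is called first, only, known or untested is meant among the compounds shown, and "the series" means these compounds.

Compound 1 `Cc1cccc2c1N(CC(=O)O)C/C(=C\c1ccccc1)C2=O` — 27.9%
Compound 2 `COc1ccc(OC)c(/C=C2\CN(CC(=O)O)c3c(C)cccc3C2=O)c1` — 5.44%
Compound 3 `CCOc1ccc(/C=C2\CN(CC(=O)O)c3c(Cl)cccc3C2=O)cc1` — 59.1%

Of the compounds shown here, three sharing one core have been measured in an assay on HL-60 cells for inhibition of glutathione S-transferase P (Homo sapiens), read by spectrophotometry, tested at 20 uM; a higher number here means more inhibition at the concentration tested (going by the name of the read-out), a lower number less inhibition. In this assay compound 1 gives 27.9%, the second highest of the three numbers. Compound 2, which carries two methoxy groups on its phenyl, gives 5.44%, and that gap to compound 1 lies beyond the usual scatter. Compound 3, with an ethoxy group on its phenyl and chlorine rather than methyl on the core, gives 59.1%, again beyond the scatter from compound 1, this time upward. Within the data shown here, since compounds 2 and 3 each differ from compound 1 in more than one place, no single-change step is available among the measured compounds.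

The next compound, compound 4 `Cc1ccc(/C=C2\CN(CC(=O)O)c3c(C)cccc3C2=O)cc1`, differs from compound 1 in one place only: methyl in place of hydrogen on an aromatic carbon. The phenyl of compound 1 thus becomes a 4-methylphenyl.

Among the measured compounds shown here, no measured pair shows what such a change does here. A modest rise is expected, in line with the higher value of compound 3 which carries a group at the same place, so the step is estimated as a number 7.1 percentage points higher from compound 1 to compound 4 (within the scatter). Compound 4 is therefore expected to give about 35%, within a range from 15% to 55%.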

Compound 4, a percentage reported as inhibition, at one concentration (the size of the read-out at that concentration, not a potency): 46.8%
Beside the measured number, compound 4's estimate is 11.8 percentage points below it; measured number inside the range.
By their numbers in this assay, from the lowest: compound 2; then compound 1; then compound 4; then compound 3.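

In this assay turning the phenyl into a 4-methylphenyl gives a number 18.9 percentage points higher from compound 1 to compound 4 (beyond the scatter) from a single methyl on this aromatic carbon, para to a large group. Among these compounds, compounds 2 and 3 could not show this, as each differs from compound 1 in more than one place and the effect of their phenyl groups cannot be separated from their other changes; this pair gives the first reading of one change at this position, and it shows that the position responds to even the smallest carbon group. Nothing available here accounts for the rise, which remains an observation about this one pair.

From the compounds shown here alone, it remains open whether the rise is particular to methyl or would also come with another group at this place, such as a fluorine atom, an amine or a longer chain like propyl. Going by these compounds, it is also open whether the same change would have a similar effect on a core carrying chlorine rather than methyl, as the core of compound 3 does.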